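Swapping a fused lactam for a methylated pyrrolidinone

A few compounds are considered here, and "the series" means these few. Any claim that something is new, unique, unknown or untested is made for them only; others in the source may bear on it.

The study measures solubility in a physicochemical assay for solubility, read by LC-MS, in phosphate buffer, with a stated time of 24 h, at pH 7.4; on this read-out higher numbers stand for higher solubility and lower numbers for lower solubility. Compound 1 `CNC(=O)c1cc(-c2cnc(NCc3c(F)ccc4c3CCO4)c3cn[nH]c(=O)c23)n(C)n1` gives 7000 nM in this assay. Compound 3 `O=C1c2ccccc2CN1c1cnc(NCc2c(F)ccc3c2CCO3)n2cnnc12` gives 4000 nM, the lowest of the two numbers reported, with compound 1 its nearest neighbour at a gap within the scatter. Compound 2 `O=C1CCCN1c1cnc(NCc2c(F)ccc3c2CCO3)c2cn[nH]c(=O)c12` is reported only as a limit of the assay, < 2000 nM, as noted at the limit of < 2000 nM in this assay, at which 1 of the 3 values shown sits.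

Among the measured compounds shown here, the one measured step, an at least 3.5-fold lower number from compound 1 to compound 2 (0.54 log units; beyond the scatter), put a 2-oxopyrrolidin-1-yl onto the core in place of the pyrazole amide and lowered the number. Compound 4 `C[C@H]1CC(=O)N(c2cnc(NCc3c(F)ccc4c3CCO4)n3cnnc23)C1` differs from compound 3 by a group of 7 heavy atoms (5 carbon, 1 nitrogen, 1 oxygen; one five-membered non-aromatic ring with 1 hetero atom) in place of a group of 10 heavy atoms (8 carbon, 1 nitrogen, 1 oxygen; one five-membered non-aromatic ring with 1 hetero atom, one six-membered aromatic ring of carbon only), on an aromatic carbon. The entering group again is a small lactam, but the leaving group here is a fused lactam rather than the pyrazole amide, so the measured step bears on it only loosely. A change within the scatter is therefore expected, with a 1.3-fold higher number from compound 3 to compound 4 (0.10 log units; within the scatter) as the expected step. Compound 4 is estimated at 5000 nM, within a range from 2000 nM to 12000 nM.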

Compound 4, solubility: 200000 nM
Estimate against measurement, compound 4: 40-fold (1.60 log units) below; measured number outside the range, above it.
By their numbers in this assay, from the lowest: compounds 3 and 1 (each within the scatter of the next); then compound 4. At a limit, below all of these: compound 2.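

On an aromatic carbon of the shared core, 4-methyl-2-oxopyrrolidin-1-yl taking the place of a larger group that also holds a six-membered aromatic ring of carbon only gives a 50-fold higher number from compound 3 to compound 4 (1.70 log units; beyond the scatter) in this assay and shows that the group on this carbon can shift the read-out by a large step. The earlier step, with 2-oxopyrrolidin-1-yl entering from compound 1 to compound 2, went the other way, so a small lactam entering does not set the direction by itself, although those two steps start from different compounds and different leaving groups. No measurement shown here gives a reason for the large step.

The compounds shown leave open whether the step follows the loss of the aromatic ring, the 4-methyl group or its defined stereocentre. They also leave open how a morpholine or a carboxylic acid on this carbon would read.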